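The compounds below may be only part of what the source reports. "The series", "measured", "known", "first", "only" and "open" are said of these compounds alone.

Measured compounds:
compound 1 `O[C@@H]1Cc2cc(Cl)ccc2N[C@H](c2ccccc2)C1`, in an ADME assay on THP-1 cells (Homo sapiens) for cytotoxicity, read by MTT assay, with a stated time of 72 h (a lower number here means that less compound is tolerated, a higher number that more compound is tolerated), 188000 nM;
compound 2 `O[C@@H]1Cc2cc(F)ccc2N[C@H](c2ccccc2)C1`, in this assay > 300000 nM;
compound 3 `O[C@@H]1Cc2ccccc2N[C@H](c2ccc(Cl)cc2)C1`, in this assay 114000 nM.

The value of compound 2 in this assay is a limit of the assay, not a number, as the limit of > 300000 nM in this assay, at which 1 of the 3 values shown sits, shows. Compound 1 and compound 2 differ in one place, (fluoro in place of chloro on an aromatic carbon), and the step was an at least 1.5-fold higher number from compound 1 to compound 2 (0.20 log units; that floor lies within the scatter). Compound 3 and compound 4 `O[C@@H]1Cc2ccccc2N[C@H](c2ccc(F)cc2)C1` differ by the same kind of change, (fluoro in place of chloro on an aromatic carbon), though here the place is para to a large group rather than meta and para to a fused ring. The difference between the two cores is not broken down here. Compound 3 stands near compound 1 in this assay. Compound 4 is expected to give a step of a 1.8-fold higher number from compound 3 to compound 4 (0.24 log units; within the scatter) in this assay, resting on the step from compound 1 to compound 2 being an at least 1.5-fold higher number from compound 1 to compound 2 (0.20 log units; that floor lies within the scatter). Compound 4 is therefore estimated at 200000 nM in this assay.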

Compound 4, half-maximal cytotoxic concentration: > 300000 nM
Compound 4: a limit, no number (the forecaster's own chance of this, stated with the estimate: 30%); middle value at least 1.5-fold (0.17 log units) from the limit.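

In this assay compound 4 gives > 300000 nM, a limit of the assay and not a number. Fluoro in place of chloro on an aromatic carbon gave an at least 2.6-fold higher number from compound 3 to compound 4 (0.42 log units; beyond the scatter), so on this core the step clears the scatter, whereas on the core of compound 1 its floor does not. This shows that the change gave no lower number on either core, but it does not show that the size of the step carries from one core to the other: the same change on two cores in this assay, an at least 1.5-fold higher number (0.20 log units; that floor lies within the scatter) from compound 1 to compound 2 and an at least 2.6-fold higher number (0.42 log units; beyond the scatter) from compound 3 to compound 4; the limit leaves it open whether they differ

The compounds shown leave open how a bromo or a methyl group would read in place of the fluoro. They also leave open whether the change would carry to a core bearing an amine in place of the hydroxyl.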